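Hydroxyalkyl amide change: compound 2 to compound 3

The source may report more compounds than this note shows. Statements on the series, on what has been measured and on what is new or still open speak of the compounds shown alone.

Measured in a functional assay on PC-3 cells (Homo sapiens) for antiproliferative activity, read by MTT assay, with a stated time of 24 h; a higher number here means a weaker inhibitor, a lower number a stronger inhibitor:
- compound 1 `CCn1c(C(=O)NCCNC(=O)OC(C)(C)C)ccc1C(CC)(CC)c1ccc(OCS(=O)(=O)c2ccccc2)c(C)c1`: > 50000 nM (a limit of the assay)
- compound 2 `CCn1c(C(=O)NCCO)ccc1C(CC)(CC)c1ccc(OCS(=O)(=O)c2ccccc2)c(C)c1`: 17700 nM

Within the data shown here, compound 2, at 17700 nM, holds the only actual number so far. Compound 1 gave only a limit.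

Compound 3 `CCn1c(C(=O)NC(C)(C)CO)ccc1C(CC)(CC)c1ccc(OCS(=O)(=O)c2ccccc2)c(C)c1` carries 1-(hydroxymethyl)-1-methylethyl in place of 2-hydroxyethyl on an amide-type nitrogen. Among the measured compounds shown here, the one measured step bearing on this is an at least 2.8-fold lower number from compound 1 to compound 2 (0.45 log units; beyond the scatter), where hydroxy replaced (tert-butoxycarbonyl)amino. That step is a different change and a loose guide, though it shows that this assay responds to the group on this amide. Compound 3 keeps the hydroxy, so no step beyond the scatter is expected, with a slight lean towards a higher number. The estimate amounts to an expected 1.2-fold higher number from compound 2 to compound 3 (0.09 log units; within the scatter). For compound 3 the estimated value is 22000 nM, with an expected range of 9000 nM to 50000 nM.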

Compound 3, half-maximal inhibitory concentration: 9850 nM
Estimate against measurement, compound 3: 2.2-fold (0.35 log units) above; low and high end bracket the measured number.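

In this assay, the change on the amide-type nitrogen gives a 1.8-fold lower number from compound 2 to compound 3 (0.25 log units; within the scatter), so 1-(hydroxymethyl)-1-methylethyl, with 5 heavy atoms against 3 for 2-hydroxyethyl, is tolerated without a step beyond the scatter. Setting the same group in place of 2-((tert-butoxycarbonyl)amino)ethyl gives an at least 5.0-fold lower number from compound 1 to compound 3 (0.70 log units; beyond the scatter), so a second hydroxy-bearing amide now stands clear of the carbamate-bearing chain. That step starts from a limit and its full size stays unfixed: the limit of > 50000 nM in this assay, at which 1 of the 3 values shown sits.

Whether the hydroxy itself matters on this chain stays open, as neither a free amine nor a carboxylic acid in its place is among the compounds shown. Nor does one pair of hydroxy compounds show whether a longer chain would move the number beyond the scatter.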